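A Five-Membered Ring Replaces a Six-Membered One

The source may hold more compounds than are shown below. What is called first, only, known or untested is meant among the compounds shown, and "the series" means these compounds.

In a functional assay on HEK293 cells with D(4) dopamine receptor (Homo sapiens) as the target, read by FLIPR (on this read-out lower numbers stand for smaller maximal responses and higher numbers for larger maximal responses), compound 1 `CCO/N=C(\CCN1CCN(c2ncccc2C)CC1)c1ccccc1` gives 49%, and compound 2 `CCO/N=C(\CCN1CCN(c2ncccn2)CC1)c1ccccc1` gives 26%. Within the data shown here, compound 2 therefore stands lowest of the two numbers measured so far; its nearest neighbour is compound 1, which sits higher, beyond the scatter. Among the measured compounds shown here, the one known step, a number 23 percentage points lower from compound 1 to compound 2 (beyond the scatter), came from changing the aromatic ring on an amine nitrogen in a ring. Compound 3 `CCO/N=C(\CCN1CCN(c2nccs2)CC1)c1ccccc1` carries the same kind of change at the same place: 1,3-thiazol-2-yl in place of pyrimidin-2-yl on an amine nitrogen in a ring. The earlier step bears on it only loosely: the group that enters here differs from both groups seen before, so no firm direction can be drawn, and a step of modest size either way would not surprise. The expected step is a number 4 percentage points higher from compound 2 to compound 3 (within the scatter), so compound 3 is estimated at 30%, within a range from 10% to 55%.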

Compound 3, largest response reached (reported as efficacy), in percent of the reference or control that the assay uses: 72%
For compound 3 the middle estimate is 42 percentage points below the measured one; the measured number lies above the stated range.
By their numbers in this assay, from the lowest: compound 2; then compound 1; then compound 3.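

At this place, on an amine nitrogen in a ring, a single aromatic group can move the maximal response much further than the first pair suggested: in this assay, 1,3-thiazol-2-yl in place of pyrimidin-2-yl gives a number 46 percentage points higher from compound 2 to compound 3 (beyond the scatter), and in place of 3-methylpyridin-2-yl it gives a number 23 percentage points higher from compound 1 to compound 3 (beyond the scatter). The five-membered ring with its sulfur atom therefore stands above both six-membered rings, so among these three compounds the response rises or falls with the choice of this one group. No measurement at hand explains this rise.

The size of the ring and the presence of sulfur change together here, so the three compounds cannot separate them. Also open, from the compounds shown here alone, is how a 1,3-oxazol-2-yl group, with oxygen in place of sulfur, would read at this place.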